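A few compounds are considered here, and "the series" means these few. Any claim that something is new, unique, unknown or untested is made for them only; others in the source may bear on it.

Compound 1 `Cc1nn(-c2ncnc3nc[nH]c23)c2c1C(C(=O)Nc1ccccc1)CC(=O)N2` is examined in a functional assay on HEK293 cells for agonist activity at G-protein coupled receptor 39 (Homo sapiens), read by scintillation proximity assay and inositol phosphate accumulation, with a stated time of 75 min, in the presence of a further agent that is not named here (a lower number here means that less compound is needed, a higher number that more compound is needed for the effect), where compound 1 gives 10 nM. Among the three measured compounds it holds the highest number: compound 2 `Cc1nn(-c2ncnc3nc[nH]c23)c2c1C(OCc1ccccc1C#N)CC(=O)N2` gives 8 nM, and compound 3 `Cc1nn(-c2ncnc3nc[nH]c23)c2c1C(OCc1ccc(C#N)cc1)CC(=O)N2` gives 4 nM. The step of a 1.3-fold lower number from compound 1 to compound 2 (0.10 log units; within the scatter) lies within the scatter, whereas a 2.5-fold lower number from compound 1 to compound 3 (0.40 log units; beyond the scatter) is modest but beyond it; between the two benzyl ethers, a 2.0-fold lower number from compound 2 to compound 3 (0.30 log units; within the scatter) stays within the scatter. Compound 4 `Cc1nn(-c2ncnc3nc[nH]c23)c2c1C(C(=O)N(C)c1nccs1)CC(=O)N2` differs from compound 1 at one place: methyl(1,3-thiazol-2-yl)amino in place of anilino on a carbonyl carbon. For the measured compounds named here, none of the measured steps bears directly on this change: each of them replaces the whole phenylcarbamoyl group on the saturated ring carbon, and none alters only the group on the carbonyl carbon. All measured steps are small, the largest being a 2.5-fold lower number from compound 1 to compound 3 (0.40 log units; beyond the scatter). Going by the values given here, with no closer precedent, the expected step is a 1.5-fold higher number from compound 1 to compound 4 (0.18 log units; within the scatter), that is, no change beyond the scatter. Compound 4 is therefore estimated at 15 nM, with a range from 4 nM to 60 nM.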

Compound 4, half-maximal effective concentration: 18 nM
Estimate against measurement, compound 4: 1.2-fold (0.08 log units) below; low and high end bracket the measured number.
By their numbers in this assay, from the lowest: compounds 3, 2, 1 and 4 (each within the scatter of the next, the first and the last beyond it).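

In this assay, methyl(1,3-thiazol-2-yl)amino on the carbonyl carbon gives a 1.8-fold higher number from compound 1 to compound 4 (0.26 log units; within the scatter), so at this place the six-membered carbon ring and the hydrogen-bond donor of anilino can both go without a change beyond the scatter. Compared with the benzyl ethers, the new amide stands further off than compound 1 does: a 2.3-fold higher number from compound 2 to compound 4 (0.35 log units; beyond the scatter) and a 4.5-fold higher number from compound 3 to compound 4 (0.65 log units; beyond the scatter) are both modest but beyond the scatter, whereas compound 1 is beyond the scatter only of compound 3. No measurement at hand gives a cause for these steps.

The compounds shown do not separate the added methyl from the change of ring, which methyl(phenyl)amino or 1,3-thiazol-2-ylamino on the same carbonyl carbon would do. On these data alone, whether a saturated amine such as piperidine is accepted there also remains open.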